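Sulfonamide aryl swap on the shared core

The source may hold more compounds than are shown below. What is called first, only, known or untested is meant among the compounds shown, and "the series" means these compounds.

Three analogues carrying the same core have been read in a functional assay on HCT-116 cells (Homo sapiens) for antiproliferative activity, read by MTT assay, with a stated time of 72 h; on this read-out lower numbers stand for stronger inhibition and higher numbers for weaker inhibition. Compound 1 `COc1ccc(C(=O)N(C)c2ccc3[nH]c(-c4n[nH]c5ccccc45)cc3n2)cc1` gives 29500 nM. Compound 2 `CN(c1ccc2[nH]c(-c3n[nH]c4ccccc34)cc2n1)S(=O)(=O)c1ccc(Br)cc1` gives 9850 nM, and the step of a 3.0-fold lower number from compound 1 to compound 2 (0.48 log units; beyond the scatter) is the only one in the set that clears the scatter. Compound 3 `COc1ccc(S(=O)(=O)N(C)c2ccc3[nH]c(-c4n[nH]c5ccccc45)cc3n2)cc1OC` gives 16700 nM; on this read-out compound 3 stands second highest of the three numbers, its nearest neighbour being compound 2 and its furthest compound 1, with both gaps within the scatter, so no order among them can be claimed, and the step of a 1.7-fold higher number from compound 2 to compound 3 (0.23 log units; within the scatter) is likewise within the scatter.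

Compound 4 `CN(c1ccc2[nH]c(-c3n[nH]c4ccccc34)cc2n1)S(=O)(=O)c1ccc(OC(F)(F)F)cc1` is not yet measured. Relative to compound 3 the change is 4-(trifluoromethoxy)phenyl in place of 3,4-dimethoxyphenyl on a sulfonyl sulfur. The step that bears on it is a 1.7-fold higher number from compound 2 to compound 3 (0.23 log units; within the scatter), which exchanged one aryl group on the same sulfonyl sulfur for another and stayed within the scatter; the change to compound 4 is of the same kind, one aryl on the sulfonyl sulfur for another. Nothing in the set separates one such aryl from the next beyond the scatter. For compound 4 the expectation in this assay is therefore a step of a 1.5-fold lower number from compound 3 to compound 4 (0.18 log units; within the scatter), not beyond the scatter, landing between the numbers of compound 2 and compound 3. The estimate for compound 4 is 11000 nM, with a range from 5000 nM to 25000 nM.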

Compound 4, half-maximal inhibitory concentration: 6040 nM
Estimate against measurement, compound 4: 1.8-fold (0.26 log units) above; low and high end bracket the measured number.
By their numbers in this assay, from the lowest: compounds 4, 2, 3 and 1 (each within the scatter of the next, the first and the last beyond it).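

The aryl group on the sulfonyl sulfur can move the number beyond the scatter in this assay: the change to 4-(trifluoromethoxy)phenyl gives a 2.8-fold lower number from compound 3 to compound 4 (0.44 log units; beyond the scatter), whereas the earlier exchange at this place did not clear it. The two aryl groups compared directly with the 4-bromophenyl of compound 2 both stay within the scatter of it, since trifluoromethoxy in place of bromo gives a 1.6-fold lower number from compound 2 to compound 4 (0.21 log units; within the scatter) and the step to compound 3 is also within the scatter, so only compound 3 and compound 4 are separated and the three sulfonamides do not fall into a clear order. No measurement is available that explains the separation between compound 3 and compound 4.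

The compounds shown leave open how far this place tolerates groups of a different kind, such as a phenyl carrying an amine or a carboxylic acid, a plain unsubstituted phenyl, or a longer alkyl chain in place of the aryl on the sulfonyl sulfur. They also leave open whether the 4-(trifluoromethoxy)phenyl gain over 3,4-dimethoxyphenyl would hold with hydrogen in place of the methyl on the sulfonamide nitrogen.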